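From acetoxy to a carboxy-ended ester at one site

The source may hold more compounds than are shown below. What is called first, only, known or untested is meant among the compounds shown, and "the series" means these compounds.

Compounds measured so far in a functional assay on MCF7 cells (Homo sapiens) for antiproliferative activity, read by MTT assay, with a stated time of 72 h; on this read-out lower numbers stand for stronger inhibition and higher numbers for weaker inhibition
- compound 1 `CC1=CCC2C(CC[C@@]2(C)O)C(C)(C)C1CC[C@@H]1[C@@]2(C)CC[C@@H](O)C(C)(C)O[C@@H]2CC[C@]1(C)O` gives 44500 nM
- compound 2 `CC(=O)O[C@H]1CC[C@]2(C)[C@H](CC[C@@](C)(O)[C@H]2CC[C@@H]2C(C)=CC[C@H]3[C@H](CC[C@]3(C)O)C2(C)C)OC1(C)C` gives 47900 nM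
- compound 3 `CC(=O)O[C@H]1CC[C@]2(C)[C@H](CC[C@@](C)(O)[C@H]2CC[C@@H]2C(C)=CC[C@H]3[C@H](CC[C@]3(C)OC(C)=O)C2(C)C)OC1(C)C` gives 39200 nM

Compound 2 at 47900 nM lies within the scatter of both compound 1 and compound 3, so it holds no clear rank among them. Compound 4 `CC1=CC[C@H]2[C@H](CC[C@]2(C)O)C(C)(C)[C@@H]1CC[C@H]1[C@]2(C)CC[C@H](OC(=O)CCC(=O)O)C(C)(C)O[C@H]2CC[C@@]1(C)O` has not yet been measured. Its difference from compound 2 is carboxymethyl in place of hydrogen on a saturated chain carbon bound to a carbonyl carbon, which means that acetoxy becomes ((2-carboxyethyl)carbonyl)oxy.

Within the data shown here, only one measured step offers guidance. It is a 1.2-fold lower number from compound 2 to compound 3 (0.09 log units; within the scatter), with acetyl in place of hydrogen on an oxygen on a saturated carbon. This is an ester change, but it lies at another place on the shared core and adds no carboxy group, so it bears on compound 4 only loosely. Among the measured compounds shown here, no measured compound tests a carboxy-ended chain. With so little evidence, no step beyond the scatter is expected in this assay, and neither direction is favoured. The expected change is a 1.1-fold lower number from compound 2 to compound 4 (0.03 log units; within the scatter). For compound 4 the estimated value is 45000 nM, with an expected range from 22000 nM to 90000 nM.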

Compound 4, half-maximal inhibitory concentration: > 50000 nM
Compound 4: only a limit was reported; the forecaster's own chance of this, stated with the estimate: 10%; at least 1.1-fold (0.04 log units) between middle value and limit.
By their numbers in this assay, from the lowest: compounds 3, 1 and 2 (each within the scatter of the next). At a limit, above all of these: compound 4.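

Compound 4 gives > 50000 nM in this assay, which is a limit and not a number. The step reads an at least 1.0-fold higher number from compound 2 to compound 4 (0.01 log units; that floor lies within the scatter), so extending the acetoxy group to ((2-carboxyethyl)carbonyl)oxy gives no sign of stronger inhibition, and how much weaker compound 4 may be cannot be read. The earlier compounds held no carboxy-ended chain, and this is the first reading for one, which ends at the assay's limit: the limit of > 50000 nM in this assay, at which 1 of the 4 values shown sits.

The compounds shown leave open whether the free carboxylic acid end itself matters, which a methyl ester of that end could test. They also leave open whether a longer chain, or an ester ending in an amine, would give a value that can be read in this assay.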